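Replacing the Octyl Chain on the Carbonyl of Compound 3

The compounds below may be only part of what the source reports. "The series", "measured", "known", "first", "only" and "open" are said of these compounds alone.

Of the compounds shown here, three have been measured in an assay on isolated protein for binding affinity to histamine H2 receptor (Homo sapiens); a higher number here means a weaker inhibitor, a lower number a stronger inhibitor. Among the compounds with values here, compound 1 `CCCCCC(=O)c1ccc(OCCCN2CCN(C(=O)N3CCOCC3)CC2)cc1` gives 17800 nM, and compound 2 `CCCCCC(=O)c1ccc(OCCCN2CCN(S(=O)(=O)c3ccc(C#N)cc3)CC2)cc1` gives 12300 nM; the only single-point step, a 1.4-fold lower number from compound 1 to compound 2 (0.16 log units; within the scatter), changes a group on the ring amine nitrogen. Compound 3 `CCCCCCCCC(=O)c1ccc(OCCCN2CCN(C(=O)OCC)CC2)cc1` gives 2690 nM, the lowest number of the three. Compound 4 `CCOC(=O)N1CCN(CCCOc2ccc(C(=O)/C=C/c3ccc(OC)cc3)cc2)CC1` differs from compound 3 at the carbonyl carbon: 2-(4-methoxyphenyl)ethenyl in place of octyl on a carbonyl carbon. Within the data shown here, no measured step touches this carbonyl position, so nothing measured bears directly on the change; the one known step lies elsewhere and is within the scatter. With no guidance, compound 4 is expected to stay near compound 3, a step of a 1.3-fold higher number from compound 3 to compound 4 (0.11 log units; within the scatter), estimated at 3500 nM within a range from 800 nM to 15000 nM.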

Compound 4, inhibition constant: 6760 nM
Beside the measured number, compound 4's estimate is 1.9-fold (0.29 log units) below it; the range from low to high includes it.
By their numbers in this assay, from the lowest: compound 3; then compounds 4, 2 and 1 (each within the scatter of the next, the first and the last beyond it).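

Within the data shown here, the carbonyl carbon is the first place where a single change gives a step beyond the scatter in this assay, with 2-(4-methoxyphenyl)ethenyl in place of octyl giving a 2.5-fold higher number from compound 3 to compound 4 (0.40 log units; beyond the scatter). The change adds an aromatic ring, a double bond outside aromatic rings and a hydrogen-bond acceptor together, so the step cannot be assigned to any one of them. Nothing available gives a reason for this step.

Going by these compounds, it remains open which of these features carries the step. A plain phenyl or a butyl chain on this carbonyl carbon would help to separate them.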